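Two Inactive Lactones and a Sulfonamide Variant

This account rests on a few compounds, and the source may have more. Where it says the series, first, only, none or still open, it means among the compounds named here.

Compound 1 `CCCCCc1ccc(-c2cn(C/C=C3\OC(=O)C(OCc4ccccc4)=C3OCc3ccccc3)nn2)cc1`: > 100000 nM
Compound 2 `COc1ccccc1-c1cn(C[C@H](O)[C@H]2OC(=O)C(OCc3ccccc3)=C2OCc2ccccc2)nn1`: > 100000 nM

Both compounds were tested in a functional assay on A549 cells (Homo sapiens) for antiproliferative activity, read by MTT assay, with a stated time of 72 h; on this read-out lower numbers stand for stronger inhibition and higher numbers for weaker inhibition. For compound 1 the value > 100000 nM is a limit of the assay, not a number. Compound 2 likewise gives > 100000 nM, again a limit. For the measured compounds named here, compound 2 therefore stands at the limit of > 100000 nM in this assay, at which 2 of the 2 values shown sit, and no measured step separates it from any other compound here.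

Compound 3 `O=C1O[C@H]([C@@H](O)Cn2cc(CNS(=O)(=O)c3ccc(Cl)cc3)nn2)C(OCc2ccccc2)=C1OCc1ccccc1` has not yet been measured. It differs from compound 2 in one place: (((4-chlorophenyl)sulfonyl)amino)methyl in place of 2-methoxyphenyl on an aromatic carbon. Going by the values given here, no measured step exists for a change of this kind, so there is no basis in these data to expect a gain beyond the scatter. The step of a number no higher from compound 2 to compound 3 (the limit leaves the size open) is expected to be essentially none. The estimate for compound 3 is 100000 nM, with a range from 30000 nM to 300000 nM, most likely reported again as a limit.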

Compound 3, half-maximal inhibitory concentration: 2870 nM
Beside the measured number, compound 3's estimate is 35-fold (1.54 log units) above it; measured number below the stated range.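

In this assay, exchanging the 2-methoxyphenyl group for the (((4-chlorophenyl)sulfonyl)amino)methyl group on the five-membered aromatic ring with 3 nitrogen gives an at least 34-fold lower number from compound 2 to compound 3 (1.54 log units; beyond the scatter). On these data alone, compound 2 sits at a limit of the assay, so the full size of this step stays unknown, but the group at this position can clearly separate a compound with a measurable number from one without. Compound 3 is the only compound shown that gives a number rather than a limit: the limit of > 100000 nM in this assay, at which 2 of the 3 values shown sit.

This single change alters the linking atoms, the sulfonyl group, the amino hydrogen and the chlorine together, so the compounds shown cannot say which of these parts matters. As far as these compounds go, how a carboxamide link in place of the sulfonyl group, or a hydrogen in place of the chlorine, would read remains open.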